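Adding a second chlorine to the phenoxy ring of compound 3

The compounds below may be only part of what the source reports. "The series", "measured", "known", "first", "only" and "open" are said of these compounds alone.

Three compounds share a piperidine-linked anilide scaffold and were examined in a functional assay on HEK293 cells for antagonist activity at melanin-concentrating hormone receptor 1 (Rattus norvegicus), read by FLIPR; on this read-out higher numbers stand for weaker inhibition and lower numbers for stronger inhibition. Compound 1 `CC(=O)Nc1cccc(C2CCN(CCCC(=O)c3ccc(Cl)cc3)CC2)c1` gives 570 nM in this assay. Compound 2 `Cc1ccc(Oc2cccc(CN3CCC(c4cccc(NC(=O)C(C)C)c4)CC3)c2)cc1` carries a methyl on its phenoxy ring, but for compound 2 this assay reports "not determined" (no result reported), so no number is available. Compound 3 `CC(C)C(=O)Nc1cccc(C2CCN(Cc3cccc(Oc4ccc(Cl)cc4)c3)CC2)c1` gives 2000 nM in this assay, the highest of the two numbers recorded; compound 1 sits below it by a margin that lies beyond the usual scatter of repeated measurements.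

Compound 4 `CC(C)C(=O)Nc1cccc(C2CCN(Cc3cccc(Oc4ccc(Cl)c(Cl)c4)c3)CC2)c1` is the next step. Its difference from compound 3 is chloro in place of hydrogen on an aromatic carbon, taking the 4-chlorophenoxy group to a 3,4-dichlorophenoxy group, with the new chloro ortho to the existing chloro group and meta to a large group. Within the data shown here, no measured pair in this set shows what such a change does, so the expectation rests on compound 3 alone. The step from compound 3 to compound 4 is expected to be small, a 1.3-fold lower number from compound 3 to compound 4 (0.12 log units; within the scatter), and may well stay within the scatter. Compound 4 is therefore estimated at 1500 nM, within a range from 500 nM to 5000 nM.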

Compound 4, half-maximal inhibitory concentration: 2600 nM
Compound 4: middle estimate off by 1.7-fold (0.24 log units), on the low side, within the range that was stated.
By their numbers in this assay, from the lowest: compound 1; then compounds 3 and 4 (each within the scatter of the next).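

In this assay, among these compounds, taking the 4-chlorophenoxy group to the 3,4-dichlorophenoxy group gives a 1.3-fold higher number from compound 3 to compound 4 (0.11 log units; within the scatter), the first step in this set that can be read between two measured compounds. It shows that on this scaffold, an added chloro on this aromatic carbon, ortho to a chloro group and meta to a large group, leaves compound 3 and compound 4 indistinguishable on this read-out, so this position accepts the extra chlorine with no difference beyond repeat measurement. No evidence at hand bears on this result, and the two values alone cannot say what lies behind it.

One step with one substituent cannot show whether this carbon is insensitive in general, and a methoxy group, an amine or a carboxylic acid in the same place might or might not separate from compound 3. Compound 2 has no number, so the methyl on its phenoxy ring cannot be compared with the chloro of compound 3, and that step cannot be read.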